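Replacing hydroxy in compound 1: step to compound 4

A few compounds are considered here, and "the series" means these few. Any claim that something is new, unique, unknown or untested is made for them only; others in the source may bear on it.

In a functional assay on HEK293 cells (Homo sapiens) for cytotoxicity (on this read-out lower numbers stand for higher toxicity in this test and higher numbers for lower toxicity in this test), compound 1 `COc1ccc([C@H]2CC(=O)N(c3cccc(O)c3)C2)cc1OC1CCCC1` gives > 10000 nM, which is a limit and not a number. Compound 2 `COc1ccc([C@H]2CC(=O)N(c3ccccc3C#N)C2)cc1OC1CCCC1` gives > 10000 nM, also a limit. Compound 3 `COc1ccc([C@H]2CC(=O)N(c3ccccc3C(F)(F)F)C2)cc1OC1CCCC1` gives > 10000 nM, again a limit. For the measured compounds named here, the series so far therefore consists of the limit of > 10000 nM in this assay, at which 3 of the 3 values shown sit.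

Compound 4 `COc1ccc([C@H]2CC(=O)N(c3cccc(NCC4CCOC4)c3)C2)cc1OC1CCCC1` keeps the core of compound 1 and carries ((oxolan-3-yl)methyl)amino in place of hydroxy on an aromatic carbon. Going by the values given here, no measured step covers this exact change. The nearest are a step that the two limits leave unreadable from compound 1 to compound 2 and a step that the two limits leave unreadable from compound 1 to compound 3, together with a step that the two limits leave unreadable from compound 2 to compound 3, and none of them has a readable size. Among the compounds with values here, they show only that all three compounds stay at the limit in this assay. No step beyond the scatter and no direction can be argued from them, so the expected step, a step that the limit leaves unreadable from compound 1 to compound 4, is a weak expectation of no real change. Another limit is the likely report. For compound 4 the estimated value is 20000 nM, with an expected range from 6000 nM to 60000 nM.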

Compound 4, half-maximal cytotoxic concentration: > 10000 nM
Compound 4: only a limit was reported (the forecaster's own chance of this, stated with the estimate: 85%); the middle value is on the limit's open side.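

Compound 4 gives > 10000 nM in this assay, which is a limit, so no size can be read for the step from compound 1 to compound 4. The compounds shown leave open whether any change on the shared core would give a readable value in this assay, because the series offers only this: the limit of > 10000 nM in this assay, at which 4 of the 4 values shown sit.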